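Removing the Methyl From an Inactive Cyclohexyl Urea

This account rests on a few compounds, and the source may have more. Where it says the series, first, only, none or still open, it means among the compounds named here.

Measured compounds:
compound 1, `Cc1ccc(NC(=O)N[C@H]2CC[C@H](Oc3ccc(F)cc3)CC2)cc1`, > 20000 nM
compound 2, `O=C(Nc1cccc(C(F)(F)F)c1)N[C@H]1CCCC[C@@H]1Oc1ccc(C(F)(F)F)cc1`, 3100 nM
compound 3, `O=C(Nc1cccc(C(F)(F)F)c1)N[C@H]1CC[C@H](Oc2ccc(C(F)(F)F)cc2)CC1`, 460 nM

In a functional assay on CRL2813 cells (Homo sapiens) for cytotoxicity, read by sulforhodamine B assay, with a stated time of 5 days (on this read-out lower numbers stand for stronger inhibition and higher numbers for weaker inhibition), compound 1 gives only a limit, > 20000 nM, and no number. This is the limit (the limit of > 20000 nM in this assay, at which 1 of the 3 values shown sits). Compound 3 returns a number, 460 nM. Compound 2 also returns a number, 3100 nM. Compound 1 thus stands apart from compounds 2 and 3, which both give measurable values, while compound 1 itself is placed only at the limit of this assay.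

Compound 4, `O=C(Nc1ccccc1)N[C@H]1CC[C@H](Oc2ccc(F)cc2)CC1`, differs from compound 1 by hydrogen in place of methyl on an aromatic carbon. Among the measured compounds shown here, no step of this kind has been measured among the compounds here, so the size of its effect rests on expectation alone. With compound 1 resting at a limit, the step that the limit leaves unreadable from compound 1 to compound 4 is expected to be none beyond the usual scatter. Compound 4 is therefore estimated at 25000 nM, in a range from 8000 nM to 60000 nM, with a substantial chance that this assay again reports only a limit for it.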

Compound 4, half-maximal inhibitory concentration: 20000 nM
For compound 4 the middle estimate is 1.3-fold (0.10 log units) above the measured one; low and high end bracket the measured number.
By their numbers in this assay, from the lowest: compound 3; then compound 2; then compound 4.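

In this assay compound 4 returns a measured value, 20000 nM, so this series can give a number at this level of the read-out. For compound 1 the entry > 20000 nM is a limit of the assay and not a number. The change from 4-methylphenyl to phenyl, on an aromatic carbon para to a large group, therefore shows only a number no higher from compound 1 to compound 4 (the limit leaves the size open), and its true size cannot be read because compound 1 rests at the limit: the limit of > 20000 nM in this assay, at which 1 of the 4 values shown sits.

Going by these compounds, whether an amine or a methoxy group on that same aromatic carbon would shift the value in this assay remains open. Also open is which of the several differences separating compound 4 from compound 3 accounts for the gap between their values.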